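Removing one methoxy group from a chalcone series

A few compounds are considered here, and "the series" means these few. Any claim that something is new, unique, unknown or untested is made for them only; others in the source may bear on it.

Three chalcones were tested in a functional assay on CNE-2 cells (Homo sapiens) for cytotoxicity, read by sulforhodamine B assay, with a stated time of 48 h; on this read-out higher numbers stand for weaker inhibition and lower numbers for stronger inhibition. Compound 1 `COc1cccc(/C=C/C(=O)c2cccc(-c3cccc(F)c3)c2)c1OC` gave 10000 nM, and compound 2 `COc1ccccc1/C=C/C(=O)c1cccc(-c2cccc(F)c2)c1` gave 10400 nM; the change between them, (hydrogen in place of methoxy on an aromatic carbon), produced a 1.0-fold higher number from compound 1 to compound 2 (0.02 log units; within the scatter). Compound 3 `COc1cc(/C=C/C(=O)c2ccc(N)c(-c3ccc(F)cc3)c2)cc(OC)c1OC` gave 4600 nM, the lowest of the three numbers; how its core differs from that of compound 1 is not broken down here. Compound 4 `COc1ccc(/C=C/C(=O)c2ccc(N)c(-c3ccc(F)cc3)c2)cc1OC` is not yet measured and differs from compound 3 by hydrogen in place of methoxy on an aromatic carbon, the same kind of change as before, though here the place is also meta to a methoxy group. The expected step, a 1.3-fold higher number from compound 3 to compound 4 (0.12 log units; within the scatter), rests on what compound 1 and compound 2 showed, namely a 1.0-fold higher number from compound 1 to compound 2 (0.02 log units; within the scatter). Compound 4 is therefore estimated at 6000 nM, with a range from 2500 nM to 15000 nM.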

Compound 4, half-maximal inhibitory concentration: 3510 nM
For compound 4 the middle estimate is 1.7-fold (0.23 log units) above the measured one; the range from low to high includes it.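

In this assay, hydrogen in place of methoxy on an aromatic carbon gave a 1.3-fold lower number from compound 3 to compound 4 (0.12 log units; within the scatter), so this step is small on the second core as well. The two cores show no difference in how the change behaves: the same change on two cores in this assay, a 1.0-fold higher number (0.02 log units; within the scatter) from compound 1 to compound 2 and a 1.3-fold lower number (0.12 log units; within the scatter) from compound 3 to compound 4, 1.4-fold (0.13 log units) apart, within the scatter of two such steps This shows that across these two pairs the methoxy group can be replaced by hydrogen without moving the number beyond the scatter, but it does not show how the change would behave on any other core, and two pairs establish no general rule for the series.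

The compounds shown leave open whether a hydroxyl or an ethoxy group on that aromatic carbon would behave as hydrogen does. They also leave open what removing the remaining methoxy groups would do.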